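The compounds below may be only part of what the source reports. "The series", "measured", "known", "first", "only" and "open" are said of these compounds alone.

In a functional assay on HUVEC cells (Homo sapiens) for antiproliferative activity, read by MTT assay, with a stated time of 48 h (on this read-out lower numbers stand for stronger inhibition and higher numbers for weaker inhibition), compound 1 `COc1ccc(-c2cc3ccc(OC)cc3nc2Nc2ccc(NC(=O)CN3CCCCC3)cc2)cc1` gives 23500 nM. Compound 2 `COc1ccc(-c2cc3ccc(OC)cc3nc2Nc2ccc(NC(=O)CN3CCN(C)CC3)cc2)cc1` differs from it by 4-methylpiperazin-1-yl in place of piperidin-1-yl on a saturated chain carbon bound to a carbonyl carbon, and in this assay compound 2 gives 7400 nM, so that this single change produced a 3.2-fold lower number from compound 1 to compound 2 (0.50 log units; beyond the scatter). Compound 3 `COc1ccc(-c2cc3cc(OC)ccc3nc2Nc2ccc(NC(=O)CN3CCCCC3)cc2)cc1` is built from the same atoms as compound 1, joined differently, and the difference between the two cores is not broken down here. In this assay compound 3 reaches only a limit of the assay, > 50000 nM. This is the limit of > 50000 nM in this assay, at which 1 of the 3 values shown sits. Compound 4 `COc1ccc(-c2cc3cc(OC)ccc3nc2Nc2ccc(NC(=O)CN3CCN(C)CC3)cc2)cc1` has not yet been measured in this assay; it differs from compound 3 by 4-methylpiperazin-1-yl in place of piperidin-1-yl on a saturated chain carbon bound to a carbonyl carbon, the same change, in the same place, as that between compound 1 and compound 2. For compound 4 a step of comparable size is expected, an at least 1.7-fold lower number from compound 3 to compound 4 (0.25 log units; that floor lies within the scatter), because the same change earlier produced a 3.2-fold lower number from compound 1 to compound 2 (0.50 log units; beyond the scatter). Because compound 3 stands only at a limit, > 50000 nM, the starting point is uncertain, and compound 4 may itself return a limit. The estimate for compound 4 in this assay is 28000 nM. That expectation for compound 4 spans from 12000 nM to 60000 nM.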

Compound 4, half-maximal inhibitory concentration: 7400 nM
For compound 4 the middle estimate is 3.8-fold (0.58 log units) above the measured one; measured number outside the range, below it.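

In this assay the exchange of piperidin-1-yl for 4-methylpiperazin-1-yl on the core of compound 3 gave an at least 6.7-fold lower number from compound 3 to compound 4 (0.82 log units; beyond the scatter), so the direction seen on the core of compound 1 also appeared on this second core. Set side by side, the two steps read: the same change on two cores in this assay, a 3.2-fold lower number (0.50 log units; beyond the scatter) from compound 1 to compound 2 and an at least 6.7-fold lower number (0.82 log units; beyond the scatter) from compound 3 to compound 4; the limit leaves it open whether they differ. Compound 3 stands at > 50000 nM, which is a limit of the assay and not a number, so its step gives only a floor, and these two pairs show a shared direction but not a shared size: the limit of > 50000 nM in this assay, at which 1 of the 4 values shown sits.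

The compounds shown leave open whether the same direction would hold for other groups on the saturated chain carbon bound to a carbonyl carbon, such as morpholin-4-yl or a piperazin-1-yl without its methyl group. They also leave open whether it would survive a longer chain in that place, or on a third core.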